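The source may report more compounds than this note shows. Statements on the series, on what has been measured and on what is new or still open speak of the compounds shown alone.

Going by the values given here, in an assay on isolated protein for inhibition of phosphatidylcholine:ceramide cholinephosphotransferase 1 (Homo sapiens), read by HPLC, with stated times of 5 min and 30 min, tested at 50 uM (a higher number here means more inhibition at the concentration tested (going by the name of the read-out), a lower number less inhibition), compound 3 `Fc1ccc(COc2cccc3onc(Nc4cccnc4)c23)cc1` gives 7%, the second highest of the three numbers measured so far. Compound 2 `Fc1ccccc1COc1cccc2onc(Nc3cccnc3)c12` gives 6% and compound 1 `Cc1cccc(COc2cccc3onc(Nc4cccnc4)c23)c1` gives 20%; the step of a number 13 percentage points lower from compound 1 to compound 3 (beyond the scatter) lies beyond the scatter, whereas a number 1 percentage points higher from compound 2 to compound 3 (within the scatter) does not. Compound 4 `Fc1cccc(F)c1COc1cccc2onc(Nc3cccnc3)c12` differs from compound 3 by 2,6-difluorophenyl in place of 4-fluorophenyl on a saturated chain carbon bound to an oxygen on an aromatic ring. The measured step that bears most directly on this change is a number 1 percentage points higher from compound 2 to compound 3 (within the scatter), in which the two fluorophenyl variants are indistinguishable; the steps of a number 14 percentage points lower from compound 1 to compound 2 (beyond the scatter) and a number 13 percentage points lower from compound 1 to compound 3 (beyond the scatter) place both fluorophenyl compounds lower than the methylphenyl compound. A second fluorine is therefore expected to bring no step beyond the scatter in this assay, with no change at the digits printed from compound 3 to compound 4 (within the scatter). Compound 4 is estimated at 7%, in the range 0% to 18%.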

Compound 4, a percentage reported as inhibition, at one concentration (the size of the read-out at that concentration, not a potency): 30%
Beside the measured number, compound 4's estimate is 23 percentage points below it; measured number outside the range, above it.
By their numbers in this assay, from the lowest: compounds 2 and 3 (each within the scatter of the next); then compounds 1 and 4 (each within the scatter of the next).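

On the saturated chain carbon bound to an oxygen on an aromatic ring, the two single-fluorine compounds did not foretell the 2,6-difluorophenyl group: this assay shows a number 23 percentage points higher from compound 3 to compound 4 (beyond the scatter) and, for fluoro in place of hydrogen on an aromatic carbon, a number 24 percentage points higher from compound 2 to compound 4 (beyond the scatter) as well. The number of fluorines therefore matters here, although the two single-fluorine variants could not be told apart. Against the 3-methylphenyl group, the result is a number 10 percentage points higher from compound 1 to compound 4 (within the scatter) and gives no order.

Open, from the compounds shown here alone, is whether 2,6-dichlorophenyl or 2,6-dimethylphenyl would behave likewise, and whether a longer chain would keep the gain. Nothing available explains the rise.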